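Phenyl in place of a piperidine on a receptor antagonist

The source may report more compounds than this note shows. Statements on the series, on what has been measured and on what is new or still open speak of the compounds shown alone.

Compound 1 `CCCCc1sc(-c2ccc(Oc3ccc(Cl)cc3)cc2)nc1-c1ccc(OCC2CCCN(CC)C2)cc1`: 55.9%
Compound 2 `CCCCc1sc(-c2ccc(OCCCN(C)C)cc2)nc1-c1ccc(Oc2ccc(Cl)cc2)cc1`: 46.2%

In an assay on isolated protein for antagonist activity at advanced glycosylation end product-specific receptor (Homo sapiens), read by ELISA, with a stated time of 60 min, tested at 10 uM (a lower number here means less inhibition, a higher number more inhibition at the concentration tested (going by the name of the read-out)), compound 1 gives 55.9% and compound 2 gives 46.2%. The two numbers lie within the usual scatter of each other, so neither compound can be set apart from the other on this assay. Compound 3 `CCCCc1sc(-c2ccc(Oc3ccc(Cl)cc3)cc2)nc1-c1ccc(OCc2ccccc2)cc1` differs from compound 1 by phenyl in place of 1-ethylpiperidin-3-yl on a saturated chain carbon bound to an oxygen on an aromatic ring. Among the compounds with values here, no measured pair isolates such a change, so its size cannot be read from the data; a modest downward step is expected, a number 15.9 percentage points lower from compound 1 to compound 3 (beyond the scatter). Compound 3 is therefore estimated at 40%, within a range from 15% to 65%.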

Compound 3, a percentage reported as inhibition, at one concentration (the size of the read-out at that concentration, not a potency): 2.4%
Compound 3: middle estimate off by 37.6 percentage points, on the high side; measured number outside the range, below it.
By their numbers in this assay, from the lowest: compound 3; then compounds 2 and 1 (each within the scatter of the next).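

In this assay, putting phenyl in place of 1-ethylpiperidin-3-yl on the saturated chain carbon bound to an oxygen on an aromatic ring gives a number 53.5 percentage points lower from compound 1 to compound 3 (beyond the scatter). This position therefore does not accept just any ring: the change removes the nitrogen of the leaving group, and compound 3 keeps only 2.4%. Compound 1 and compound 2 could not show this, as they differ in more than one place.

On these data alone, whether the nitrogen or the ring type counts stays open, and a cyclohexyl or a pyridyl group in the same place would help to separate the two. Nothing measured here explains the size of the step.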